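The compounds below may be only part of what the source reports. "The series", "measured", "known", "first", "only" and "open" are said of these compounds alone.

Of the compounds shown here, three built on one shared core have been measured in a functional assay on CHO cells with adenosine receptor A1 (Homo sapiens) as the target, read by cAMP accumulation and immunoassay, with a stated time of 6 min, tested at 1 uM; on this read-out lower numbers stand for a stronger effect and higher numbers for a weaker effect at the one concentration tested. Compound 1 `Nc1scc(CN2CCN(c3cccc(Cl)c3Cl)CC2)c1C(=O)c1ccc(Cl)cc1` gives -57% in this assay. Compound 2 `Nc1scc(CN2CCN(c3ccc([N+](=O)[O-])cc3)CC2)c1C(=O)c1ccc(Cl)cc1` gives -8.3%, and compound 3 `Nc1scc(CN2CCN(c3ccc(Cl)c(C(F)(F)F)c3)CC2)c1C(=O)c1ccc(Cl)cc1` gives -47%. Compound 3 stands second highest of the three numbers: its nearest neighbour is compound 1, as a number 10 percentage points higher from compound 1 to compound 3 (within the scatter), and its furthest is compound 2, as a number 38.7 percentage points lower from compound 2 to compound 3 (beyond the scatter).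

Compound 4 `Nc1scc(CN2CCN(c3cccnc3)CC2)c1C(=O)c1ccc(Cl)cc1` differs from compound 3 in one place: pyridin-3-yl in place of 4-chloro-3-(trifluoromethyl)phenyl on an amine nitrogen in a ring. All three measured steps concern the group on this same amine nitrogen in a ring. They were a number 48.7 percentage points higher from compound 1 to compound 2 (beyond the scatter), a number 10 percentage points higher from compound 1 to compound 3 (within the scatter) and a number 38.7 percentage points lower from compound 2 to compound 3 (beyond the scatter); two of them show that swapping this group can move the number a great deal, while one left it within the scatter. Within the data shown here, no measured compound carries a pyridin-3-yl, so the direction rests on analogy only. On what is shown, the step expected for compound 4 is a number 27 percentage points higher from compound 3 to compound 4 (beyond the scatter), towards a weaker effect. Compound 4 is therefore estimated at -20%, with a range from -45% to 5%.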

Compound 4, a percentage reported as activity, at one concentration (the size of the read-out at that concentration, not a potency): -2.7%
Compound 4: the middle estimate sits 17.3 percentage points below what was measured; measured number inside the range.
By their numbers in this assay, from the lowest: compounds 1 and 3 (each within the scatter of the next); then compounds 2 and 4 (each within the scatter of the next).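

In this assay the change to pyridin-3-yl on this amine nitrogen in a ring is large, with a number 44.3 percentage points higher from compound 3 to compound 4 (beyond the scatter) and a number 54.3 percentage points higher from compound 1 to compound 4 (beyond the scatter) as the two steps from the chlorine-bearing groups, while a number 5.6 percentage points higher from compound 2 to compound 4 (within the scatter) shows that it does not separate from 4-nitrophenyl. The four compounds now fall into two sets without an exception: compounds 1 and 3, whose aromatic ring on this nitrogen carries chlorine, and compounds 2 and 4, whose ring carries none. No measurement shown here explains this split.

From the compounds shown here alone, whether the chlorine itself goes with the stronger effect stays open, and a plain phenyl or a chloropyridinyl on this nitrogen would test it. Also open, going by these compounds, is whether any group without a six-membered aromatic ring, such as a benzyl or a simple methyl, would fall with either set.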